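Chain length and amine size on a trimethoxyphenyl chromone core

The source may hold more compounds than are shown below. What is called first, only, known or untested is meant among the compounds shown, and "the series" means these compounds.

Measured compounds in a functional assay on LNCaP cells (Homo sapiens) for antiproliferative activity, read by WST assay, with a stated time of 3 days; on this read-out lower numbers stand for stronger inhibition and higher numbers for weaker inhibition:
- compound 1, `CCN(CC)CCCOc1c(-c2cc(OC)c(OC)c(OC)c2)oc2ccccc2c1=O`: 37600 nM
- compound 2, `CCN(CC)CCCCCOc1c(-c2cc(OC)c(OC)c(OC)c2)oc2ccccc2c1=O`: 10000 nM
- compound 3, `CCCN(CCC)CCCCCOc1c(-c2cc(OC)c(OC)c(OC)c2)oc2ccccc2c1=O`: 7600 nM

Among these three, compound 1 gives the highest number, and its steps to both other compounds lie beyond the scatter: a 3.8-fold lower number from compound 1 to compound 2 (0.58 log units; beyond the scatter) and a 4.9-fold lower number from compound 1 to compound 3 (0.69 log units; beyond the scatter). Between compound 2 and compound 3 the difference is small: a 1.3-fold lower number from compound 2 to compound 3 (0.12 log units; within the scatter).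

The unmeasured compound 4 is `CCCCCN(CCCCC)CCCCOc1c(-c2cc(OC)c(OC)c(OC)c2)oc2ccccc2c1=O`. Its difference from compound 1 is (dipentylamino)methyl in place of diethylamino on a saturated chain carbon, three bonds along the chain from an oxygen on an aromatic ring

Among the compounds with values here, the steps that bear on this change are those from compound 1. Both of them lengthen the chain between the aromatic oxygen and the nitrogen and both lowered the number by a modest amount, while enlarging the two alkyl groups on the nitrogen, as seen from compound 2 to compound 3, added little. Compound 4 lengthens the chain by less than compound 2 or compound 3 but carries much larger groups on the nitrogen. A modest lowering in this assay is therefore expected, roughly of the size of the two earlier steps from compound 1, namely a 4.7-fold lower number from compound 1 to compound 4 (0.67 log units; beyond the scatter). Compound 4 is accordingly estimated at 8000 nM, with a range from 2500 nM to 25000 nM.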

Compound 4, half-maximal inhibitory concentration: 9700 nM
Compound 4: middle estimate off by 1.2-fold (0.08 log units), on the low side, and the stated range covers the measured number.
By their numbers in this assay, from the lowest: compounds 3, 4 and 2 (each within the scatter of the next); then compound 1.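

In this assay, putting (dipentylamino)methyl in place of diethylamino, on a saturated chain carbon three bonds along the chain from an oxygen on an aromatic ring, gives a 3.9-fold lower number from compound 1 to compound 4 (0.59 log units; beyond the scatter) and so shows that this place accepts an entering group of 12 heavy atoms, against 5 for the group leaving, with the number still beyond the scatter from that of compound 1. The earlier compounds shown here reached only dipropylamino, whereas dipentylamino brings no separation from them: the data give a 1.3-fold higher number from compound 3 to compound 4 (0.11 log units; within the scatter) and a 1.0-fold lower number from compound 2 to compound 4 (0.01 log units; within the scatter) and both steps lie within the scatter, so compounds 2, 3 and 4 form one group despite their different chains and amines. Nothing available accounts for these steps.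

The step to compound 4 alters chain and amine together, so the shares of the two remain unseparated, and a compound pairing dipentylamino with the chain of compound 1 would be needed to divide them. Also open, going by these compounds, is how a ring amine such as piperidine or morpholine, or a chain longer than that of compound 2, would behave at this place.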